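The source may hold more compounds than are shown below. What is called first, only, known or untested is meant among the compounds shown, and "the series" means these compounds.

Two macrolides with the same outer groups but a different link into the ring were tested in a functional assay on MDA-MB-231 cells (Homo sapiens) for antiproliferative activity, read by resazurin assay, with a stated time of 72 h; on this read-out higher numbers stand for weaker inhibition and lower numbers for stronger inhibition. Compound 1, with structure `CC(=O)N[C@H](C)[C@@H](O)[C@@H](C)[C@@H]1OC(=O)CC/C=C(C)\C=C\[C@]2(C)CCC=C[C@@H]2/C=C(C)/C=C/[C@H]1C`, carries a saturated two-carbon stretch between the lactone carbonyl and the first double bond of the ring. In this assay compound 1 reaches only the limit of > 5000 nM, which is a limit of the assay and not a number. Compound 2, with structure `CC(=O)N[C@H](C)[C@@H](O)[C@@H](C)[C@@H]1OC(=O)/C=C/C=C(C)\C=C\[C@]2(C)CCC=C[C@@H]2/C=C(C)/C=C/[C@H]1C`, has a double bond in that same stretch. In this assay compound 2 gives 63 nM, the only number shown here. The other value, that of compound 1, is the limit of > 5000 nM in this assay, at which 1 of the 2 values shown sits.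

Compound 3, with structure `CC(=O)N[C@H](C)[C@@H](O)[C@@H](C)[C@@H]1OC(=O)/C=C/C=C(C)/C=C/[C@]2(C)CCC=C[C@@H]2/C=C(C)/C=C/[C@H]1C`, is the next step. The change from compound 2 to compound 3 is the two compounds have the same atoms and bonds and differ only in configuration as drawn: 1 of 12 stereo elements differ; a double bond is drawn Z in compound 2 and E in compound 3. Among the measured compounds shown here, no pair of measured compounds differs in this way, so the size of the step is uncertain; a change of ring geometry of this kind is expected to cost activity, perhaps by a large margin, and the step is estimated as a 6.3-fold higher number from compound 2 to compound 3 (0.80 log units; beyond the scatter). Compound 3 is therefore expected to give about 400 nM, somewhere between 60 nM and 3000 nM.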

Compound 3, half-maximal inhibitory concentration: 384 nM
The estimate for compound 3 lay 1.0-fold (0.02 log units) above the measured number; the measured number falls inside the stated range.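

Among the compounds shown here, changing one double bond from Z to E, with every atom and bond left in place, gives a 6.1-fold higher number from compound 2 to compound 3 (0.78 log units; beyond the scatter) in this assay, and this is the first step here with a measured number at both ends. Since nothing else differs, the weaker inhibition can be traced to the configuration of this single double bond alone, so the shape drawn at this one place matters as well as the atoms present: the fact that compounds 2 and 3 differ only in the configuration as drawn. For the compounds shown here, compound 1 remains the only compound at a limit of the assay, which is not a number: the limit of > 5000 nM in this assay, at which 1 of the 3 values shown sits.

The compounds shown leave open whether the other double bond drawn with a defined configuration would respond to the same kind of change as strongly, and whether the step would keep its size in a compound lacking the double bond that separates compound 1 from compound 2. They also leave open how the outer part of the molecule contributes, for instance whether a free amine or a longer chain in place of the acetamide would keep the activity.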